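The compounds below may be only part of what the source reports. "The series", "measured", "known", "first", "only" and "open" are said of these compounds alone.

Compound 1 `COC[C@H](C)[C@H](C)C(c1ccc(O)c(OC)c1)c1ccc(O)c(OC)c1` gives 72000 nM in a functional assay on HeLa cells (Homo sapiens) for cytotoxicity, read by WST assay, with a stated time of 48 h (a higher number here means a weaker inhibitor, a lower number a stronger inhibitor), the only plain number shown here. Compound 2 `COc1cc(C(c2ccc(O)c(OC)c2)[C@@H](CO)C(C)C)ccc1O` reaches only a limit in this assay, > 100000 nM. For the measured compounds named here, the single measured step, an at least 1.3-fold higher number from compound 1 to compound 2 (0.14 log units; that floor lies within the scatter), ends at the limit of > 100000 nM in this assay, at which 1 of the 2 values shown sits. Compound 3 `COc1cc(C(c2ccc(O)c(OC)c2)[C@H](C)[C@@H](C)CO)ccc1O` differs from compound 1 by 2-(hydroxymethyl)-1-methylpropyl in place of 2-(methoxymethyl)-1-methylpropyl on a saturated chain carbon bound to two aromatic carbons, again trading a methoxymethyl for a hydroxymethyl on that chain. Since the similar change in this assay gave an at least 1.3-fold higher number from compound 1 to compound 2 (0.14 log units; that floor lies within the scatter), a small rise in the number is expected for compound 3, a 1.3-fold higher number from compound 1 to compound 3 (0.12 log units; within the scatter). Compound 3 is estimated at 95000 nM, within 50000 nM to 200000 nM, with a fair chance that only a limit is reported.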

Compound 3, half-maximal inhibitory concentration: > 100000 nM
Compound 3 was reported as a limit; the forecaster's own chance of this, stated with the estimate: 45%; middle value at least 1.0-fold (0.02 log units) away from the limit.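

Replacing 2-(methoxymethyl)-1-methylpropyl with 2-(hydroxymethyl)-1-methylpropyl gives, in this assay, an at least 1.3-fold higher number from compound 1 to compound 3 (0.14 log units; that floor lies within the scatter), so the size of this change cannot yet be told. Compound 2 and compound 3 now show that both hydroxymethyl chains tried at this position end in a limit rather than a plain number: the limit of > 100000 nM in this assay, at which 2 of the 3 values shown sit. The step between those two cannot be read, since both values are limits.

On these data alone, how far the true values of compound 2 and compound 3 lie past that limit stays open. So does how an amine or a longer ether chain at this position would read.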